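The source may report more compounds than this note shows. Statements on the series, on what has been measured and on what is new or still open speak of the compounds shown alone.

Measured so far:
compound 1 `N#CC1=C(N)Oc2c(c3nc4ccccc4nc3c3ccccc23)C12C(=O)N(Cc1cnnn1-c1ccccc1Cl)c1ccccc12` — > 50000 nM
compound 2 `CC(=O)Nc1ccc(-n2nncc2CN2C(=O)C3(C(C#N)=C(N)Oc4c(N)cc5nc6ccccc6nc5c43)c3ccccc32)cc1` — > 50000 nM

In an ADME assay on L02 cells (Homo sapiens) for antiproliferative activity, read by MTT assay, with a stated time of 48 h (a lower number here means a stronger inhibitor, a higher number a weaker inhibitor), compound 1 gives only a limit, > 50000 nM. Compound 2 likewise gives only a limit in this assay, > 50000 nM. Both readings sit at the limit of > 50000 nM in this assay, at which 2 of the 2 values shown sit, so compound 2 cannot be ranked against compound 1 on these numbers; nothing separates the two. Going by the values given here, no step between two measured compounds is available for this series.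

Compound 3 `Cc1cc(C)c(-n2nncc2CN2C(=O)C3(C(C#N)=C(N)Oc4c(N)cc5nc6ccccc6nc5c43)c3ccccc32)c(C)c1` is the untested member. It differs from compound 2 in one place: 2,4,6-trimethylphenyl in place of 4-acetamidophenyl on an aromatic nitrogen. With both known values at the limit, the series gives no direction for this change, and the expectation is no step beyond the scatter. Compound 3 is expected to stay at the limit as well, the estimated step being a step that the limit leaves unreadable from compound 2 to compound 3. For compound 3 in this assay the estimate is 70000 nM, within 25000 nM to 200000 nM.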

Compound 3, half-maximal inhibitory concentration: > 50000 nM
Compound 3 was reported as a limit; the forecaster's own chance of this, stated with the estimate: 85%; the middle value does not contradict the limit.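

No step can be read between compound 2 and compound 3, as both values are limits and not numbers: the limit of > 50000 nM in this assay, at which 3 of the 3 values shown sit.

The compounds shown leave open whether changing the group on the aromatic nitrogen affects the read-out in this assay, as none of them gives a value short of the limit.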